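A few compounds are considered here, and "the series" means these few. Any claim that something is new, unique, unknown or untested is made for them only; others in the source may bear on it.

Three compounds have been measured in a functional assay on cells (Splenocyte, Mus musculus, strain BALB/c) for inhibition, read by MTT assay, with a stated time of 48 h; a lower number here means a stronger inhibitor, a higher number a weaker inhibitor:

compound 1 `CO/C(=C\c1ccccc1)C(=O)Nc1ccc(C)cc1`: 16600 nM
compound 2 `CO/C(=C\c1ccc(Cl)cc1)C(=O)Nc1ccc(Br)cc1`: 11000 nM
compound 3 `CO/C(=C\c1ccc(Cl)cc1)C(=O)Nc1ccc(C)cc1`: 12700 nM

Compound 3 sits second highest of these three numbers, but the spread is small: its nearest neighbour is compound 2, a step of a 1.2-fold higher number from compound 2 to compound 3 (0.06 log units; within the scatter), and its furthest is compound 1, a step of a 1.3-fold lower number from compound 1 to compound 3 (0.12 log units; within the scatter). Both steps lie within the scatter, so on the numbers shown the three compounds cannot be told apart.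

Compound 4 `CO/C(=C\c1ccc(Br)cc1)C(=O)Nc1ccc(C)cc1` has not yet been measured. It differs from compound 3 in one place: bromo in place of chloro on an aromatic carbon.

Going by the values given here, no measured step exchanges chloro for bromo on the same carbon. The closest guide is the pair of compound 2 and compound 3, where a methyl stands in place of a bromo on the other ring, and that step stayed within the scatter; the addition of chloro from compound 1 to compound 3 also stayed within the scatter. With halogens on this ring apparently contributing little that the assay resolves, the author expects the step of a 1.1-fold lower number from compound 3 to compound 4 (0.02 log units; within the scatter) in this assay to remain within the scatter, with no clear direction. Compound 4 is therefore estimated at 12000 nM, within a range of 6000 nM to 25000 nM.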

Compound 4, half-maximal inhibitory concentration: 12900 nM
Compound 4: the middle estimate sits 1.1-fold (0.03 log units) below what was measured, within the range that was stated.
By their numbers in this assay, from the lowest: compounds 2, 3, 4 and 1 (each within the scatter of the next).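

In this assay, the exchange of 4-chlorophenyl for 4-bromophenyl gives a 1.0-fold higher number from compound 3 to compound 4 (0.01 log units; within the scatter), the only step shown that swaps one halogen for another on this carbon, and it lies within the scatter. Measured against hydrogen on the same carbon, bromo gives a 1.3-fold lower number from compound 1 to compound 4 (0.11 log units; within the scatter), and chloro gives a 1.3-fold lower number from compound 1 to compound 3 (0.12 log units; within the scatter), so neither halogen at this position, para to a large group, can be told apart from hydrogen or from the other halogen in this assay. No experimental evidence is available to explain this result.

The compounds shown leave open whether any group on this carbon would give a step beyond the scatter, for an amine, a carboxylic acid or a methoxy group is not among them. Going by these compounds alone, they also leave open whether the same holds when the other ring changes: methyl is the only group there paired with bromo at this position, and whether bromo on both rings, or a larger group such as a phenyl ring on the other ring, would give a different number cannot be read from them.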